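This account rests on a few compounds, and the source may have more. Where it says the series, first, only, none or still open, it means among the compounds named here.

Measured so far in a functional assay on L1210 cells (Mus musculus) for cytotoxicity, with a stated time of 48 h; a lower number here means a stronger inhibitor, a higher number a weaker inhibitor:
Compound 1 `Fc1ccc(-c2nc3sc(Cc4ccc(Cl)cc4)nn3c2Br)cc1` gives only the assay limit, > 250000 nM.
Compound 2 `Clc1ccc(Cc2nn3c(Br)c(-c4ccc(Cl)cc4Cl)nc3s2)cc1` gives 31000 nM.
Compound 3 `O=[N+]([O-])c1ccc(-c2nc3sc(Cc4ccc(Cl)cc4)nn3c2Br)cc1` gives 94000 nM.

Compound 1 stands at the weak end of the three: its result is a limit, not a number (the limit of > 250000 nM in this assay, at which 1 of the 3 values shown sits). Compound 4 `N#CSc1c(-c2ccc(F)cc2)nc2sc(Cc3ccc(Cl)cc3)nn12` differs from it by cyanosulfanyl in place of bromo on an aromatic carbon. The two measured steps, an at least 8.0-fold lower number from compound 1 to compound 2 (0.90 log units; beyond the scatter) and an at least 2.6-fold lower number from compound 1 to compound 3 (0.42 log units; beyond the scatter), both alter the aryl group on the shared core and leave the bromo untouched, so neither bears on the exchange at this position. Within the data shown here, with no measured step to guide it, the expectation for compound 4 is no step beyond the scatter, an at least 1.2-fold lower number from compound 1 to compound 4 (0.09 log units; that floor lies within the scatter), and a fair chance that this assay again reports only a limit. Compound 4 is estimated at 200000 nM, within 40000 nM to 1000000 nM.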

Compound 4, half-maximal inhibitory concentration: 23000 nM
For compound 4 the middle estimate is 8.7-fold (0.94 log units) above the measured one; the whole stated range lies above it.
By their numbers in this assay, from the lowest: compounds 4 and 2 (each within the scatter of the next); then compound 3. At a limit, above all of these: compound 1.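

Among these compounds, the bromo position, untouched in the earlier steps, turns out to matter in this assay: with the 4-fluorophenyl group kept, cyanosulfanyl in place of bromo gives an at least 10-fold lower number from compound 1 to compound 4 (1.03 log units; beyond the scatter). This exchange alone brings the series out of the inactive range, so the aryl group is not the only place that moves the number. The size is only a floor, since compound 1 gives a limit and not a number: the limit of > 250000 nM in this assay, at which 1 of the 4 values shown sits.

As far as these compounds go, whether the sulfur or the nitrile carries the change stays open; methylsulfanyl, a nitrile directly on the ring or an amine at this carbon would separate them. Also open, from the compounds shown here alone, is whether cyanosulfanyl acts the same way alongside 2,4-dichlorophenyl.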